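The source may hold more compounds than are shown below. What is called first, only, known or untested is meant among the compounds shown, and "the series" means these compounds.

Working notes on the series. Compound 1 `O=C(Nc1ccc(Cl)cc1)Nc1ccc(Oc2ccc(-c3nccs3)cc2)cc1` carries 4-chlorophenyl on the amide-type nitrogen of the shared core. In a functional assay on MDA-MB-231 cells (Homo sapiens) for inhibition, read by MTT assay and WST assay, with a stated time of 72 h, tested at 10 uM (a higher number here means more inhibition of growth at the concentration tested, a lower number less inhibition of growth), compound 1 gives 32.5%, the lowest of the two numbers available. Compound 3 `O=C(Nc1ccc(Oc2ccc(-c3nccs3)cc2)cc1)Nc1cccc(C(F)(F)F)c1` gives 64.1% in this assay, and a number 31.6 percentage points higher from compound 1 to compound 3 (beyond the scatter). Compound 2 `O=C(Nc1ccccc1)Nc1ccc(Oc2ccc(-c3nccs3)cc2)cc1` gives "not determined" (no result reported) in this assay. Compound 4 `O=C(Nc1ccc(Oc2ccc(-c3nccs3)cc2)cc1)Nc1cc(C(F)(F)F)ccc1Cl` is not yet measured; its change from compound 1 is 2-chloro-5-(trifluoromethyl)phenyl in place of 4-chlorophenyl on an amide-type nitrogen. Within the data shown here, the one measured step that bears on this is the change from compound 1 to compound 3, which was large and upward; the group entering in compound 4 also carries a trifluoromethyl. A rise of comparable size is therefore expected, a number 22.5 percentage points higher from compound 1 to compound 4 (beyond the scatter). Compound 4 is estimated at 55%, range 35% to 75%.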

Compound 4, percent growth inhibition at one concentration: 60.4%
Compound 4: middle estimate off by 5.4 percentage points, on the low side, and the stated range covers the measured number.
By their numbers in this assay, from the lowest: compound 1; then compounds 4 and 3 (each within the scatter of the next).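

A second group carrying trifluoromethyl on the amide-type nitrogen also gives a higher number, with a number 27.9 percentage points higher from compound 1 to compound 4 (beyond the scatter) in this assay, so the rise is not confined to compound 3. Chloro in place of hydrogen on an aromatic carbon is tolerated at this position, with a number 3.7 percentage points lower from compound 3 to compound 4 (within the scatter) and no difference to read. As far as these compounds go, whether trifluoromethyl itself is needed stays open, as does whether a nitrile or a methoxy group on that ring could take its place. No measurement at hand bears on why these steps occur.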